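This account rests on a few compounds, and the source may have more. Where it says the series, first, only, none or still open, it means among the compounds named here.

Measured so far:
- compound 1, `C(=N/OCc1ccccc1)\c1c(-c2ccccc2)[nH]c2ccccc12`: 23.3%
- compound 2, `C#Cc1c(-c2ccccc2)[nH]c2ccccc12`: 88%

Both were tested in an assay on isolated protein for inhibition of Aromatase (Homo sapiens), read by fluorescence, using NADPH, with a stated time of 30 min, tested at 50 uM; a lower number here means less inhibition, a higher number more inhibition at the concentration tested (going by the name of the read-out). Compound 2 stands highest of the two numbers, and its nearest neighbour, compound 1, lies well below it, beyond the usual scatter. Compound 3, `O/N=C/c1c(-c2ccccc2)[nH]c2ccccc12`, is not yet measured. It differs from compound 2 in one place: a group of 3 heavy atoms (1 carbon, 1 nitrogen, 1 oxygen; no ring) in place of a group of 2 heavy atoms (2 carbon; no ring), on an aromatic carbon. Among the compounds with values here, no step between two measured compounds is known here, so the effect of this change is untested. A downward step is expected because compound 1 gives only 23.3% in this assay. The expected step is a number 33 percentage points lower from compound 2 to compound 3 (beyond the scatter). Compound 3 is estimated at 55%, within 25% to 85%.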

Compound 3, a percentage reported as inhibition, at one concentration (the size of the read-out at that concentration, not a potency): 40.4%
For compound 3 the middle estimate is 14.6 percentage points above the measured one; measured number inside the range.
By their numbers in this assay, from the lowest: compound 1; then compound 3; then compound 2.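

In this assay, putting the new group of 3 heavy atoms in place of ethynyl on this aromatic carbon gives a number 47.6 percentage points lower from compound 2 to compound 3 (beyond the scatter), so this position responds strongly to what it carries. With hydrogen in place of benzyl on the oxygen, the result is a number 17.1 percentage points higher from compound 1 to compound 3 (beyond the scatter), so the benzyl group does not account for all of the loss. Nothing available here explains either step. The compounds shown leave open whether ethynyl is specially suited to this carbon, or whether a nitrile or a small methyl group would hold the inhibition seen with compound 2.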